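Removing a Methyl from Two Related Cores

This account rests on a few compounds, and the source may have more. Where it says the series, first, only, none or still open, it means among the compounds named here.

Compound 1 `Oc1cc(-c2ccc(Cl)cc2)nc2ncccc12`: 33900 nM
Compound 2 `Cc1ccnc2nc(-c3ccc(Cl)cc3)cc(O)c12`: 3980 nM
Compound 3 `COc1ccccc1-c1cc(O)c2ccc(C)nc2n1`: a limit of > 100000 nM

In a functional assay on 786-0 cells (Homo sapiens) (on this read-out higher numbers stand for weaker inhibition of growth and lower numbers for stronger inhibition of growth), compound 2 gives 3980 nM. Compound 1 differs by hydrogen in place of methyl on an aromatic carbon, and the result is an 8.5-fold higher number from compound 2 to compound 1 (0.93 log units; beyond the scatter). Compound 3 has a different core; how its core differs from that of compound 2 is not broken down here. In this assay compound 3 gives only a limit, > 100000 nM, at which one of the three values sits (the limit of > 100000 nM in this assay, at which 1 of the 3 values shown sits).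

Compound 4 `COc1ccccc1-c1cc(O)c2cccnc2n1` is not yet measured. It differs from compound 3 by hydrogen in place of methyl on an aromatic carbon. This is the same kind of change as from compound 2 to compound 1, but the place is not identical: there the methyl sat ortho to a fused ring and opposite the ring nitrogen, here it sits next to the ring nitrogen and para to a fused ring. Since compound 3 already sits at a limit, and since the step of an 8.5-fold higher number from compound 2 to compound 1 (0.93 log units; beyond the scatter) weakened inhibition, compound 4 is expected to be weaker still, with an expected step that the limit leaves unreadable from compound 3 to compound 4. The estimate for compound 4 is 300000 nM, most likely again reported only as a limit.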

Compound 4, concentration for 50% growth inhibition: 36300 nM
Estimate against measurement, compound 4: 8.3-fold (0.92 log units) above; measured number below the stated range.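

In this assay, removing the methyl gives an at least 2.7-fold lower number from compound 3 to compound 4 (0.44 log units; beyond the scatter), so on this core the change goes with stronger inhibition of growth, whereas on the other core it went with weaker inhibition. The same swap of hydrogen for methyl therefore does not carry over from one core to the other, even in direction: the same change on two cores in this assay, an 8.5-fold higher number (0.93 log units; beyond the scatter) from compound 2 to compound 1 and an at least 2.7-fold lower number (0.44 log units; beyond the scatter) from compound 3 to compound 4, at least 23-fold (1.37 log units) apart, beyond the scatter of two such steps

Compound 3 gives > 100000 nM, which is a limit, so the new step has no exact size, and the two pairs differ both in the place of the methyl and in the rest of the molecule, so these results do not show which of the two matters.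

On these data alone, it remains open how an ethyl group, an amine or a carboxylic acid in the same place would behave on either core. Also open, as far as these compounds go, is whether a methyl moved to the other place on the same core would give the opposite result.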